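From a Limit to a Number: Forecasting Compound 4

The source may report more compounds than this note shows. Statements on the series, on what has been measured and on what is new or still open speak of the compounds shown alone.

Compound 3 `COc1ccc(N2C(=O)N(Cc3ccc(F)cc3Cl)c3ccccc3S2(=O)=O)cc1OC` stands at the bottom of this small set in an assay on isolated protein for displacement of a labelled ligand from Orexin/Hypocretin receptor type 1 (Homo sapiens), with a stated time of 90 min; a lower number here means a stronger inhibitor, a higher number a weaker inhibitor: compound 3 gives only the limit of > 2510 nM, a bound of the assay and not a measured number. For the measured compounds named here, compound 2 `COc1ccc(N2C(=O)N(Cc3c(F)cc(F)cc3F)c3ccccc3S2(=O)=O)cc1OC`, which carries the 2,4,6-trifluorobenzyl instead, gives 50.1 nM in this assay, and the one measured single-change step is an at least 50-fold higher number from compound 2 to compound 3 (1.69 log units; beyond the scatter). Going by the values given here, compound 1 `COc1cc(F)c(CN2C(=O)N(c3cc(OC)nc(OC)c3)S(=O)(=O)c3ccccc32)c(F)c1`, with a 2,6-difluoro-4-methoxybenzyl and a different aryl on the other ring nitrogen, gives 1 nM in this assay; no single-change step links compound 1 to the others, so its value can only be noted alongside theirs.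

Compound 4 `COc1cc(F)c(CN2C(=O)N(c3ccc(OC)c(OC)c3)S(=O)(=O)c3ccccc32)c(Cl)c1` differs from compound 3 in one place: 2-chloro-6-fluoro-4-methoxyphenyl in place of 2-chloro-4-fluorophenyl on a saturated chain carbon bound to an amide-type nitrogen in a ring. That change restores a second halogen on the benzyl ring, the feature whose loss accompanied the large at least 50-fold higher number from compound 2 to compound 3 (1.69 log units; beyond the scatter), and adds the methoxy that the benzyl of compound 1 carries. Because the limit of > 2510 nM in this assay, at which 1 of the 3 values shown sits, places compound 3 at the assay limit, the true size of the step cannot be read exactly, but a much lower number is expected, estimated as an at least 120-fold lower number from compound 3 to compound 4 (2.09 log units; beyond the scatter). Compound 4 is therefore expected to give about 20 nM in this assay, with a range from 3 nM to 150 nM.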

Compound 4, inhibition constant: 0.398 nM
Estimate against measurement, compound 4: 50-fold (1.70 log units) above; measured number outside the range, below it.
By their numbers in this assay, from the lowest: compound 4; then compound 1; then compound 2. At a limit, above all of these: compound 3.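

Changing only the group on the saturated chain carbon bound to an amide-type nitrogen in the ring, with the rest of the molecule unchanged, gives in this assay an at least 6300-fold lower number from compound 3 to compound 4 (3.79 log units; beyond the scatter). Compound 3 gives only a limit of the assay, so this step is a bound and not an exact size: the limit of > 2510 nM in this assay, at which 1 of the 4 values shown sits. For the compounds shown here, the earlier compounds showed only that a change at this place could raise the number, whereas the step of a 130-fold lower number from compound 2 to compound 4 (2.10 log units; beyond the scatter) shows that the 2-chloro-6-fluoro-4-methoxyphenyl group also lowers it well past the 2,4,6-trifluorophenyl group, so this place can move the number strongly in both directions.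

The step from 2-chloro-4-fluorobenzyl to 2-chloro-6-fluoro-4-methoxybenzyl brings in a fluorine and a methoxy together, and the compounds shown do not separate what each contributes. They also leave open whether an ethoxy, a hydroxyl or an amine in place of the methoxy would keep a number this low.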